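This account rests on a few compounds, and the source may have more. Where it says the series, first, only, none or still open, it means among the compounds named here.

Measured so far in a functional assay on ZR-75-1 cells (Homo sapiens) for inhibition, read by sulforhodamine B assay; on this read-out lower numbers stand for stronger inhibition of growth and higher numbers for weaker inhibition of growth:

- compound 1 `COc1ccc(-c2ccc(-c3ccc(-c4nc5cc(C)ccc5[nH]4)cc3)cc2)cc1OC`: 3100 nM
- compound 2 `Fc1ccc(-c2ccc(-c3ccc(-c4nc5ccccc5[nH]4)cc3)cc2)cc1`: 100000 nM
- compound 3 `FC(F)(F)Oc1ccc(-c2ccc(-c3ccc(-c4nc5ccccc5[nH]4)cc3)cc2)cc1`: 100000 nM

Compound 3 stands level with compound 2, and together they hold the highest number of the three, which means weak inhibition of growth. Compound 1 differs from both in more than one place, and its lower number cannot be tied to any single change.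

The next structure is compound 4 `CN(C)c1ccc(-c2ccc(-c3ccc(-c4nc5ccccc5[nH]4)cc3)cc2)cc1`. It keeps everything in compound 3 except one group, with dimethylamino in place of trifluoromethoxy on an aromatic carbon.

Within the data shown here, only one measured step changes a group at this place: no change at the digits printed from compound 2 to compound 3 (within the scatter). Among the measured compounds shown here, that step showed no response, but a single pair is thin evidence, and no measured compound carries dimethylamino. Compound 1, at 3100 nM, shows that a related structure can give a much lower number, so some movement in that direction remains possible. A modest step towards stronger inhibition is expected, with no change also plausible, and the estimate is a 2.5-fold lower number from compound 3 to compound 4 (0.40 log units; beyond the scatter). For compound 4 the expected value is 40000 nM, with an estimated range from 4000 nM to 100000 nM.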

Compound 4, concentration for 50% growth inhibition: 100000 nM
Estimate against measurement, compound 4: 2.5-fold (0.40 log units) below, and the stated range covers the measured number.
By their numbers in this assay, from the lowest: compound 1; then compounds 2, 3 and 4 (each within the scatter of the next).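

In this assay, the aromatic carbon para to a large group has now held fluoro, trifluoromethoxy and dimethylamino, and the number stays the same across all three: no change at the digits printed from compound 3 to compound 4 (within the scatter), and no change at the digits printed from compound 2 to compound 4 (within the scatter). One flat pair could have been a coincidence of two similar groups, but this result adds a group with different atoms, nitrogen and carbon in place of oxygen, carbon and fluorine, and the number still holds. Among these three compounds, then, the choice of group at this place makes no visible difference to growth inhibition, although nothing measured here tells why the number stays put.

Compound 1, at 3100 nM, differs from these three compounds in more than one place, so the compounds shown leave open whether its lower number belongs to its methoxy groups, to the methyl on its core, or to the two together. They also leave open whether a group of another kind at this aromatic carbon, such as a carboxylic acid or a primary amine, would move the number at all.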